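Methyl in Place of Chloro in a Cell Growth Assay

The compounds below may be only part of what the source reports. "The series", "measured", "known", "first", "only" and "open" are said of these compounds alone.

The measured compounds and their values:
compound 1 `N#Cc1c(Nc2ccccc2Cl)nc(SCc2cn(Cc3ccccc3Cl)nn2)nc1-c1ccccc1` gives 28500 nM;
compound 2 `Cc1ccccc1Nc1nc(SCc2cn(Cc3ccccc3Cl)nn2)nc(-c2ccccc2)c1C#N` gives 9740 nM;
compound 3 `N#Cc1c(Nc2ccccc2F)nc(SCc2cn(Cc3ccc(Cl)cc3)nn2)nc1-c1ccccc1` gives > 64000 nM.

These values come from a functional assay on ECa-109 cells (Homo sapiens) for inhibition, read by MTT assay, with a stated time of 72 h; on this read-out lower numbers stand for stronger inhibition and higher numbers for weaker inhibition. Compound 1 and compound 2 share a core and differ at one point: methyl in place of chloro on an aromatic carbon. That change lowered the number, and the step of a 2.9-fold lower number from compound 1 to compound 2 (0.47 log units; beyond the scatter) is modest but beyond the scatter of repeated measurements.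

For compound 3 the value is only a limit of the assay, not a number; the compound sits at the limit of > 64000 nM in this assay, at which 1 of the 3 values shown sits. How the core of compound 3 differs from that of compound 1 is not broken down here.

Compound 4 `Cc1ccc(Cn2cc(CSc3nc(Nc4ccccc4F)c(C#N)c(-c4ccccc4)n3)nn2)cc1` has not yet been measured. It relates to compound 3 by methyl in place of chloro on an aromatic carbon. Among the compounds with values here, this is the same kind of change as the one from compound 1 to compound 2, but it sits in a different place: there the methyl entered ortho to a large group, here it enters para to a large group on the 4-chlorobenzyl, which becomes 4-methylbenzyl.

Because compound 3 sits at the limit of > 64000 nM in this assay, at which 1 of the 3 values shown sits, any improvement that the change could bring starts from a limit rather than a number. The step from compound 1 to compound 2 a 2.9-fold lower number from compound 1 to compound 2 (0.47 log units; beyond the scatter) suggests a modest gain at most, so the expected step is an at least 1.2-fold lower number from compound 3 to compound 4 (0.10 log units; that floor lies within the scatter), and it may well leave compound 4 still at the limit. The estimate for compound 4 in this assay is 50000 nM, expected to fall between 15000 nM and 150000 nM.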

Compound 4, half-maximal inhibitory concentration: > 64000 nM
Compound 4: no number, only a limit; the forecaster's own chance of this, stated with the estimate: 45%; middle value at least 1.2-fold (0.10 log units) from the limit.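

Compound 3 and compound 4 both give only a limit of this assay, not a number, so no step can be read between them: the limit of > 64000 nM in this assay, at which 2 of the 4 values shown sit.

The compounds shown leave open whether changing 4-chlorobenzyl to 4-methylbenzyl alters the result at all, and whether methyl in place of chloro lowers the number anywhere other than in the step of a 2.9-fold lower number from compound 1 to compound 2 (0.47 log units; beyond the scatter).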